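Replacing a Furan with a Methoxyphenoxy Group on a Shared Core

A few compounds are considered here, and "the series" means these few. Any claim that something is new, unique, unknown or untested is made for them only; others in the source may bear on it.

In an assay on isolated protein for agonist activity at Bile acid receptor (Homo sapiens), read by AlphaScreen, with a stated time of 30 min (a lower number here means a smaller maximal response, a higher number a larger maximal response), compound 1 `Cc1ccccc1-n1nc(C)c2c1NC(=O)[C@H](C)S[C@@H]2c1ccc(-c2ccoc2)cc1` gives 40%, the second highest of the three measured numbers. Compound 2 `Cc1ccc(-n2nc(C)c3c2NC(=O)[C@H](C)S[C@@H]3c2ccc(Oc3ccccc3)cc2)cc1` gives 11%, and compound 3 `Cc1nn(-c2ccccc2C(C)C)c2c1[C@@H](c1ccc(Oc3ccccc3)cc1)S[C@@H](C)C(=O)N2` gives 174%. Among the measured compounds shown here, the only step between two measured compounds that differ in one place is a number 163 percentage points higher from compound 2 to compound 3 (beyond the scatter). Compound 4 `COc1ccccc1Oc1ccc([C@H]2S[C@@H](C)C(=O)Nc3c2c(C)nn3-c2ccccc2C)cc1` differs from compound 1 by 2-methoxyphenoxy in place of furan-3-yl on an aromatic carbon. For the measured compounds named here, no measured step changes this part of the shared core, so the step from compound 2 to compound 3 offers only indirect guidance, and the values of compound 2 and compound 3 show how widely this read-out can vary across the series. The step from compound 1 to compound 4 is therefore expected to be modest and uncertain, a number 20 percentage points higher from compound 1 to compound 4 (beyond the scatter). Compound 4 is estimated to give 60%, with a range from 15% to 160%.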

Compound 4, largest response reached (reported as efficacy), in percent of the reference or control that the assay uses: 240%
Compound 4: the middle estimate sits 180 percentage points below what was measured; measured number outside the range, above it.
By their numbers in this assay, from the lowest: compound 2; then compound 1; then compound 3; then compound 4.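

At this aromatic carbon, para to a large group, the change gives a number 200 percentage points higher from compound 1 to compound 4 (beyond the scatter) in this assay, so this site can shift the maximal response strongly, as the group on the aromatic nitrogen did earlier. No measurement available here explains this step.

On these data alone, it remains open which part of 2-methoxyphenoxy carries the step: the six-membered ring, the linking oxygen or the methoxy group. Also open, as far as these compounds go, is how an amine or a carboxylic acid at this place would compare.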